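The compounds below may be only part of what the source reports. "The series", "measured", "known", "first", "only" and "open" are said of these compounds alone.

In a functional assay on HepG2 cells (Homo sapiens) for antiproliferative activity, read by MTT assay, with a stated time of 48 h (on this read-out higher numbers stand for weaker inhibition and lower numbers for stronger inhibition), compound 1 `CN1CCN(CC(=O)Nc2ccc3ncnc(Nc4cccc(C(F)(F)F)c4)c3c2)CC1` gives > 100000 nM as a limit of the assay and not as a number. Compound 2 `CN1CCN(CC(=O)Nc2ccc3ncnc(Nc4cccc(Br)c4)c3c2)CC1` gives 25300 nM and so holds the only true number shown so far. Among the compounds with values here, the one measured step of an at least 3.9-fold lower number from compound 1 to compound 2 (0.59 log units; beyond the scatter) comes with bromo in place of trifluoromethyl and lies beyond the scatter. The move to compound 3 `CN1CCN(CC(=O)Nc2ccc3ncnc(Nc4ccc(Cl)c(C(F)(F)F)c4)c3c2)CC1` is 4-chloro-3-(trifluoromethyl)phenyl in place of 3-bromophenyl on a nitrogen on an aromatic ring and puts 4-chloro-3-(trifluoromethyl)phenyl in place of 3-bromophenyl on a nitrogen on an aromatic ring. Trifluoromethyl thus returns, so that measured step bears on this change read backwards, while no measured step covers the chloro. For compound 3 a modest rise in the number is expected, the estimated move being a 1.8-fold higher number from compound 2 to compound 3 (0.25 log units; within the scatter) in this assay on this reasoning. For compound 3 the estimated value is 45000 nM with an expected range from 15000 nM to 130000 nM at its two ends.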

Compound 3, half-maximal inhibitory concentration: 25300 nM
Compound 3: middle estimate off by 1.8-fold (0.25 log units), on the high side, within the range that was stated.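

In this assay, 4-chloro-3-(trifluoromethyl)phenyl in place of 3-bromophenyl on the nitrogen gives no change at the digits printed from compound 2 to compound 3 (within the scatter), so a larger group at this position, one that again carries trifluoromethyl, still yields a true number when chloro is also present. Chloro in place of hydrogen on an aromatic carbon gives an at least 3.9-fold lower number from compound 1 to compound 3 (0.59 log units; beyond the scatter), which shows that this single addition, and not only the removal of trifluoromethyl, can bring the number down from the limit. The real size of that step cannot be read, since compound 1 stands at a limit of the assay and not at a number: the limit of > 100000 nM in this assay, at which 1 of the 3 values shown sits.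

On these data alone, whether chloro alone on the phenyl ring, without trifluoromethyl, would give a similar number stays open. So does what an amine or a methoxy group on this ring would do in this assay.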